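Swapping butoxy for benzylamino on compound 1

The source may report more compounds than this note shows. Statements on the series, on what has been measured and on what is new or still open speak of the compounds shown alone.

Going by the values given here, in a functional assay for inhibition, with Rattus norvegicus as the target, at pH 7.35 (on this read-out lower numbers stand for stronger inhibition and higher numbers for weaker inhibition), compound 1 `CCCCOC(=O)C(=O)C(CC)NC(=O)C(CC(C)C)NC(=O)OCc1ccccc1` gives 28000 nM, the lowest number and so the strongest inhibition among the three compounds measured so far. Compound 3 `CCOC(=O)C(=O)[C@H](CC)NC(=O)[C@H](CC(C)C)NC(=O)[C@H](CC(C)C)NC(=O)c1ccc2ccccc2c1` gives 78000 nM. Compound 2 `CCCCC(NC(=O)C(CC(C)C)NC(=O)OCc1ccccc1)C(=O)C(=O)OCC` gives 150000 nM. Both of these numbers lie beyond the usual scatter from compound 1.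

Compound 4 `CCC(NC(=O)C(CC(C)C)NC(=O)OCc1ccccc1)C(=O)C(=O)NCc1ccccc1` has not yet been measured. It keeps the rest of compound 1 but carries benzylamino in place of butoxy on a carbonyl carbon, a change counted as benzylamino in place of butoxy on a carbonyl carbon.

Among the compounds with values here, no two measured compounds differ by this one swap, so the data give no direct guide to its size or direction. The estimate therefore stays close to compound 1 at 28000 nM, with a wide margin on both sides. In this assay, the expected step of a 1.3-fold higher number from compound 1 to compound 4 (0.10 log units; within the scatter) is slightly towards weaker inhibition and no larger than the scatter. Compound 4 is expected at about 35000 nM, with an estimated range from 9000 nM to 130000 nM.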

Compound 4, half-maximal inhibitory concentration: 50000 nM
Beside the measured number, compound 4's estimate is 1.4-fold (0.15 log units) below it; the measured number falls inside the stated range.
By their numbers in this assay, from the lowest: compounds 1, 4, 3 and 2 (each within the scatter of the next, the first and the last beyond it).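

In this assay, the swap of butoxy for benzylamino on a carbonyl carbon gives a 1.8-fold higher number from compound 1 to compound 4 (0.25 log units; within the scatter) and so leaves the two numbers within the usual scatter of each other. Going by these compounds alone, this is the first direct reading at this position: butoxycarbonyl and benzylcarbamoyl cannot be told apart here, even though the entering group brings a six-membered aromatic ring and a hydrogen-bond donor and has more heavy atoms. As the two compounds cannot be separated, this single swap gives no direction for further changes at this place, and nothing measured on hand bears on the reason for the result.

On these data alone, the swap alters the ring and the linking atom together, so their separate contributions remain open. Butylamino at this carbonyl carbon would separate them, while hydroxy, giving a carboxylic acid, would test a different kind of group there.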